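This account rests on a few compounds, and the source may have more. Where it says the series, first, only, none or still open, it means among the compounds named here.

Measured in an ADME assay on Vero cells (Chlorocebus sabaeus) for cytotoxicity, read by resazurin assay, with a stated time of 2 days; on this read-out higher numbers stand for lower toxicity in this test and lower numbers for higher toxicity in this test:

compound 1, `CC(=O)OC[C@H]1O[C@@H](CC(=O)/C=C/c2cccc(NC(=O)Nc3ccccc3)c2)[C@H](OC(C)=O)[C@@H](OC(C)=O)[C@@H]1OC(C)=O`, gives 180000 nM
compound 2, `O=C(/C=C/c1cccc(NC(=S)Nc2ccccc2)c1)C[C@@H]1O[C@H](CO)[C@@H](O)[C@H](O)[C@@H]1O`, gives 336000 nM

Compound 1 holds the lower of the two numbers in this assay, but compound 2 sits within the usual scatter of it, so the two values show no separation that can be read as a difference in toxicity. Compound 3, `CC(=O)OC[C@H]1O[C@@H](CC(=O)/C=C/c2cccc(NS(=O)(=O)c3ccc(C)cc3)c2)[C@H](OC(C)=O)[C@@H](OC(C)=O)[C@@H]1OC(C)=O`, has not been measured. It differs from compound 1 in one place: (4-methylphenyl)sulfonyl in place of phenylcarbamoyl on a nitrogen on an aromatic ring. No step between measured compounds covers this change, so nothing shown here tells how a replacement of this kind moves the read-out in this assay. Given that compound 1 and compound 2 differ in their own ways yet both sit in the same region, the step from compound 1 to compound 3 is expected to stay within the scatter, with a slight lean towards a lower number, as a 1.2-fold lower number from compound 1 to compound 3 (0.08 log units; within the scatter). Compound 3 is therefore estimated at 150000 nM, in a range from 60000 nM to 400000 nM.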

Compound 3, half-maximal cytotoxic concentration: 584000 nM
Beside the measured number, compound 3's estimate is 3.9-fold (0.59 log units) below it, and the stated range ends below it.
By their numbers in this assay, from the lowest: compounds 1, 2 and 3 (each within the scatter of the next, the first and the last beyond it).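

In this assay, for the compounds shown here, (4-methylphenyl)sulfonyl in place of phenylcarbamoyl on a nitrogen on an aromatic ring gives a 3.2-fold higher number from compound 1 to compound 3 (0.51 log units; beyond the scatter), the first step at this position that can be read. The position is therefore not indifferent to what the nitrogen carries: on the core of compound 1, this replacement moves the read-out modestly but beyond the scatter, in the direction of lower toxicity in this test. No measurement at hand offers an explanation for the size or direction of this step.

Going by these compounds alone, the one step changes the linking group and the ring substituent together, so the share of the sulfonyl and that of the 4-methyl group remain unresolved. Also open, as far as these compounds go, is how phenylsulfonyl, methanesulfonyl or a free amine at this nitrogen would read.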